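This account rests on a few compounds, and the source may have more. Where it says the series, first, only, none or still open, it means among the compounds named here.

Measured in a physicochemical assay for solubility, in phosphate buffer, at pH 7.4; on this read-out lower numbers stand for lower solubility and higher numbers for higher solubility:
- Compound 1 `OCC1CCN(c2nccnc2Oc2ccc(Nc3nc4ccccc4s3)cc2)CC1`: 6000 nM
- Compound 2 `OCC1CCN(c2nccnc2OC2CN(c3ncc4ccccc4n3)C2)CC1`: 174000 nM
- Compound 3 `CN(C)C1CCN(c2nccnc2OC2CN(c3ccc4ccccc4n3)C2)CC1`: 500000 nM

Compound 3 stands highest of the three, with compound 2 and compound 1 both lower by more than the scatter. Compound 4 `c1ccc(-c2nccnc2OC2CN(c3ccc4ccccc4n3)C2)nc1` differs from compound 3 in one place, with pyridin-2-yl in place of 4-(dimethylamino)piperidin-1-yl on an aromatic carbon. Going by the values given here, no measured pair isolates this change. Among the compounds with values here, a fall beyond the scatter in this assay is nevertheless expected, as no measured compound holds an aromatic ring at this place. Compound 1, at 6000 nM, shows that a non-aromatic ring there does not by itself give a high number. The expected fall is estimated as a 13-fold lower number from compound 3 to compound 4 (1.10 log units; beyond the scatter). For compound 4 the estimate is 40000 nM, with an expected range of 8000 nM to 200000 nM.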

Compound 4, solubility: 349000 nM
For compound 4 the middle estimate is 8.7-fold (0.94 log units) below the measured one; measured number above the stated range.
By their numbers in this assay, from the lowest: compound 1; then compounds 2, 4 and 3 (each within the scatter of the next, the first and the last beyond it).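

In this assay, pyridin-2-yl in place of 4-(dimethylamino)piperidin-1-yl on this aromatic carbon gives a 1.4-fold lower number from compound 3 to compound 4 (0.16 log units; within the scatter), so the change cannot be told from the scatter. Going by these compounds alone, this shows that an aromatic ring at this place, absent from the earlier compounds, can stand with a number in the same range as the non-aromatic ring of compound 3. Nothing available explains this result. The compounds shown leave open whether a phenyl ring or an open-chain amine at this place would read the same.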